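Removing the Methyl from the Linking Nitrogen of Compound 1

The source may report more compounds than this note shows. Statements on the series, on what has been measured and on what is new or still open speak of the compounds shown alone.

Measured compounds in a functional assay on A549 cells (Homo sapiens) for inhibition, read by MTT assay, with a stated time of 72 h; a higher number here means a weaker inhibitor, a lower number a stronger inhibitor:
compound 1, `CN(c1ccc(Oc2ncnc3ccsc23)cc1)c1nccc(N2CCc3ccccc3C2)n1`, gives 16200 nM
compound 2, `CN(c1ccc(Oc2ncnc3ccsc23)cc1)c1nccc(N2CCCCC2)n1`, gives 8240 nM
compound 3, `CN(c1ccc(Oc2ncnc3ccsc23)cc1)c1nccc(N2CCc3ccccc32)n1`, gives 20500 nM

All three share one core and differ only in the saturated ring attached to an aromatic carbon. Compound 1 stands between the other two on the numbers, but the step of a 2.0-fold lower number from compound 1 to compound 2 (0.29 log units; within the scatter) and the step of a 1.3-fold higher number from compound 1 to compound 3 (0.10 log units; within the scatter) both fall within the scatter, so compound 1 cannot be placed above or below either of them with confidence. Among the measured compounds shown here, only the step of a 2.5-fold higher number from compound 2 to compound 3 (0.40 log units; beyond the scatter) goes beyond the scatter, and it is modest.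

Compound 4, `c1ccc2c(c1)CCN(c1ccnc(Nc3ccc(Oc4ncnc5ccsc45)cc3)n1)C2`, differs from compound 1 by hydrogen in place of methyl on a nitrogen on an aromatic ring. For the measured compounds named here, none of the measured steps touches this nitrogen; each of them exchanges the ring on the aromatic carbon instead. Going by the values given here, there is therefore no measured step that bears on the change, and no step beyond the scatter is expected: the expected change is a 1.0-fold lower number from compound 1 to compound 4 (0.01 log units; within the scatter). Compound 4 is thus estimated at 16000 nM, with a range from 4000 nM to 64000 nM, the width reflecting the lack of a guiding step.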

Compound 4, half-maximal inhibitory concentration: 17000 nM
Beside the measured number, compound 4's estimate is 1.1-fold (0.03 log units) below it; the measured number falls inside the stated range.
By their numbers in this assay, from the lowest: compounds 2, 1, 4 and 3 (each within the scatter of the next, the first and the last beyond it).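

In this assay, putting hydrogen in place of methyl on the nitrogen on an aromatic ring gives a 1.0-fold higher number from compound 1 to compound 4 (0.02 log units; within the scatter). Among the compounds shown here, the earlier steps exchanged only the saturated ring, so this is the first reading at this nitrogen: with the 1,2,3,4-tetrahydroisoquinolin-2-yl ring in place, losing the methyl's one carbon leaves two numbers that cannot be told apart. No measurement is at hand that would explain this result.

This single pair leaves open whether the same exchange would read alike with the piperidin-1-yl ring of compound 2 or the 2,3-dihydro-1H-indol-1-yl ring of compound 3. The compounds shown also do not say how an ethyl group, a longer chain or an acetyl group on this nitrogen would read.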